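The compounds below may be only part of what the source reports. "The series", "measured", "known", "first", "only" and "open" are said of these compounds alone.

Compound 1 `c1ccc(-c2nnc(-c3cn4ccccc4n3)o2)cc1`: 22200 nM
Compound 2 `Cc1cc(Br)c2nc(-c3nnc(-c4ccccc4)o3)cn2c1`: 17800 nM

In a functional assay on PC-3 cells (Homo sapiens) for antiproliferative activity, read by MTT assay, with a stated time of 48 h (a higher number here means a weaker inhibitor, a lower number a stronger inhibitor), compound 2 gives 17800 nM and compound 1 gives 22200 nM, two values within the usual scatter of each other. Compound 3 `Cc1cc(Br)c2nc(-c3nnc(-c4ccc(N(C)C)cc4)o3)cn2c1` takes dimethylamino in place of hydrogen on an aromatic carbon of compound 2 (dimethylamino in place of hydrogen on an aromatic carbon). Among the compounds with values here, the series offers no measured step for this change, so the expectation rests on the structural change alone. A modest move toward a lower number in this assay is expected, with the estimated step being a 1.8-fold lower number from compound 2 to compound 3 (0.25 log units; within the scatter). For compound 3 the estimate is 10000 nM, with an expected range of 3000 nM to 30000 nM.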

Compound 3, half-maximal inhibitory concentration: 11200 nM
Compound 3: the middle estimate sits 1.1-fold (0.05 log units) below what was measured; low and high end bracket the measured number.
By their numbers in this assay, from the lowest: compounds 3, 2 and 1 (each within the scatter of the next).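

In this assay, dimethylamino in place of hydrogen, para to a large group on the six-membered aromatic ring of carbon only, gives the series its first one-place step: a 1.6-fold lower number from compound 2 to compound 3 (0.20 log units; within the scatter). A substituent with three heavy atoms at this position therefore leaves the number within the scatter of the hydrogen parent. On these data alone, whether a primary amine, a methoxy group or a carboxylic acid at the same place would move the number beyond the scatter remains open, as does the outcome for dimethylamino elsewhere on this ring. No measurement at hand offers an explanation for this step.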